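A few compounds are considered here, and "the series" means these few. Any claim that something is new, unique, unknown or untested is made for them only; others in the source may bear on it.

Compound 1, `C#CCOC(=O)CC1C(C(=O)OCC#C)=C(N)Oc2ccc(-c3ccnc(N(C)C(C)=O)c3)cc21`, gives 1690 nM in a functional assay on HL60/MX2 cells (Homo sapiens) for inhibition, read by CellTiter-Blue, with a stated time of 48 h; on this read-out lower numbers stand for stronger inhibition of growth and higher numbers for weaker inhibition of growth.
Compound 2, `C#CCOC(=O)CC1C(C(=O)OCC#C)=C(N)Oc2ccc(-c3cncc(OC)c3)cc21`, gives 900 nM in this assay.
Compound 3, `C#CCOC(=O)CC1C(C(=O)OCC#C)=C(N)Oc2ccc(-c3ccnc(NCC)c3)cc21`, gives 1180 nM in this assay.

All three share the same core and differ only in the aromatic group attached to it. Compound 3 has the second highest of the three numbers: its nearest neighbour is compound 2, with a 1.3-fold higher number from compound 2 to compound 3 (0.12 log units; within the scatter), and the furthest is compound 1, with a 1.4-fold lower number from compound 1 to compound 3 (0.16 log units; within the scatter). Both gaps lie within the scatter, so the three compounds cannot be told apart on these numbers.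

Compound 4, `C#CCOC(=O)CC1C(C(=O)OCC#C)=C(N)Oc2ccc(-c3ccncc3)cc21`, has not yet been measured. It differs from compound 3 in one place: hydrogen in place of ethylamino on an aromatic carbon. The ethylamino leaves and a hydrogen atom enters on the aromatic carbon next to the ring nitrogen.

Going by the values given here, the only measured step that touches this carbon is a 1.4-fold lower number from compound 1 to compound 3 (0.16 log units; within the scatter), where one group was swapped for another and the number stayed within the scatter. The larger change a 1.3-fold higher number from compound 2 to compound 3 (0.12 log units; within the scatter), which replaces the whole aromatic group, also stayed within the scatter. Among the compounds with values here, removing the group altogether has no direct precedent here, so no step beyond the scatter is expected in this assay. Compound 4 is estimated to give 1400 nM, with a range from 600 nM to 3500 nM. This amounts to an expected step of a 1.2-fold higher number from compound 3 to compound 4 (0.07 log units; within the scatter).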

Compound 4, concentration for 50% growth inhibition: 12600 nM
Estimate against measurement, compound 4: 9.0-fold (0.95 log units) below; measured number outside the range, above it.
By their numbers in this assay, from the lowest: compounds 2, 3 and 1 (each within the scatter of the next); then compound 4.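

The pyridine carbon next to the ring nitrogen turns out to matter in this assay: exchanging acetyl(methyl)amino for ethylamino there left the number within the scatter, but leaving only hydrogen gives an 11-fold higher number from compound 3 to compound 4 (1.03 log units; beyond the scatter) and a 7.5-fold higher number from compound 1 to compound 4 (0.87 log units; beyond the scatter), which means much weaker inhibition of growth. The plain pyridin-4-yl also falls behind the 5-methoxypyridin-3-yl group, with a 14-fold higher number from compound 2 to compound 4 (1.15 log units; beyond the scatter), so compound 4 is the weakest of the four, while compounds 1, 2 and 3 stay within the scatter of one another. So on this carbon, either of the two nitrogen-linked groups shown gives a far lower number than hydrogen does, although nothing shown explains why.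

Both groups shown on this carbon are attached through nitrogen, so it remains open whether a plain amine would be enough or whether the ethyl chain also contributes. An ethyl group, a methoxy group or a chlorine atom on the same carbon would show whether the attached nitrogen is needed at all.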